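This account rests on a few compounds, and the source may have more. Where it says the series, first, only, none or still open, it means among the compounds named here.

Series notes. The read-out throughout is a functional assay on HCT-116 cells (Homo sapiens) for antiproliferative activity, read by MTT assay, with a stated time of 48 h; on this read-out higher numbers stand for weaker inhibition and lower numbers for stronger inhibition. Compound 1 `COc1ccccc1/C=C/C(=O)c1nc2ccccc2[nH]1` gives 4790 nM in this assay, and compound 2 `O=C(/C=C/c1cccnc1)c1nc2ccccc2[nH]1` gives 15300 nM. Both carry the carbonyl between the alkene and the shared core. Compound 3 `OC(/C=C/c1cccc(Cl)c1)c1nc2ccccc2[nH]1` carries the alcohol at that position instead, and in this assay compound 3 reaches only > 100000 nM, which is a limit of the measurement and not a number. Where compound 3 stands is therefore known only as sitting at the limit of > 100000 nM in this assay, at which 1 of the 3 values shown sits, one of the three values shown.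

Compound 4 `COc1cccc(/C=C/C(O)c2nc3ccccc3[nH]2)c1` keeps the alcohol of compound 3 and differs from it in one place: methoxy in place of chloro on an aromatic carbon. Within the data shown here, no measured pair in the set isolates this exchange, so the size of the step in this assay is not fixed by the data; the expectation is for no step beyond the scatter, with compound 4 again near or past the limit. The step from compound 3 to compound 4 is expected to be about a number no higher from compound 3 to compound 4 (the limit leaves the size open). Compound 4 is therefore estimated at 100000 nM, within a range from 30000 nM to 300000 nM, with a real chance that only a limit is reported again.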

Compound 4, half-maximal inhibitory concentration: > 100000 nM
Compound 4: a limit, no number (the forecaster's own chance of this, stated with the estimate: 70%); the middle value lies on the limit itself.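

Compound 3 and compound 4 both sit at a limit in this assay, not at a number, so no step between them can be read: the limit of > 100000 nM in this assay, at which 2 of the 4 values shown sit.

The compounds shown leave open how methoxy and chloro on an aromatic carbon compare, and what the alcohol alone does in place of the carbonyl, since no pair shown isolates that exchange.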